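This account rests on a few compounds, and the source may have more. Where it says the series, first, only, none or still open, it means among the compounds named here.

Three compounds have so far been tested in a functional assay on NCI-H1581 cells (Homo sapiens) for inhibition, read by MTT assay, with a stated time of 48 h, tested at 10 uM; a higher number here means more inhibition at the concentration tested (going by the name of the read-out), a lower number less inhibition:

compound 1, `COc1cc(Br)ccc1Nc1cc(NC(=O)Nc2c(Cl)cccc2Cl)ncn1`: 47.3%
compound 2, `CCc1cccc(Nc2cc(NC(=O)Nc3cc(OC)cc(OC)c3)ncn2)c1`: 27.7%
compound 3, `COc1cc(NC(=O)Nc2cc(Nc3ccc(Br)cc3OC)ncn2)cc(OC)c1`: 20.1%

Compound 1 stands highest of these three numbers; the nearest is compound 2 and the furthest compound 3, and both gaps lie beyond the usual scatter. The step from compound 1 to compound 3 is a number 27.2 percentage points lower from compound 1 to compound 3 (beyond the scatter), a modest drop. That step alters the group on the amide-type nitrogen.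

Compound 4, `Cc1cc(F)cc(Nc2cc(NC(=O)Nc3c(Cl)cccc3Cl)ncn2)c1`, is not yet measured. It differs from compound 1 in one place: 3-fluoro-5-methylphenyl in place of 4-bromo-2-methoxyphenyl on a nitrogen on an aromatic ring.

Going by the values given here, only one measured step touches the same nitrogen on an aromatic ring: a number 7.6 percentage points lower from compound 2 to compound 3 (within the scatter), which stayed within the scatter. The step of a number 27.2 percentage points lower from compound 1 to compound 3 (beyond the scatter) altered a different part of the molecule and so does not bear directly on this change. On this slim basis, a change at this nitrogen is expected to move the read-out little, if at all, so the step is estimated as a number 4.3 percentage points lower from compound 1 to compound 4 (within the scatter), not beyond the scatter. Compound 4 is therefore expected to give about 43% in this assay, with a range from 25% to 60%.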

Compound 4, a percentage reported as inhibition, at one concentration (the size of the read-out at that concentration, not a potency): 65.1%
Estimate against measurement, compound 4: 22.1 percentage points below; the whole stated range lies below it.
By their numbers in this assay, from the lowest: compounds 3 and 2 (each within the scatter of the next); then compound 1; then compound 4.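

The group on a nitrogen on an aromatic ring can matter in this assay: with 2,6-dichlorophenyl kept on the amide-type nitrogen, 3-fluoro-5-methylphenyl in place of 4-bromo-2-methoxyphenyl gives a number 17.8 percentage points higher from compound 1 to compound 4 (beyond the scatter) and so a clear rise. Going by these compounds alone, the only earlier change at this nitrogen, a number 7.6 percentage points lower from compound 2 to compound 3 (within the scatter) with 3,5-dimethoxyphenyl on the amide-type nitrogen, had suggested little effect, so the earlier pair does not hold for this position in every setting. Compound 4 now stands highest of the four, which shows that 4-bromo-2-methoxyphenyl is not needed for a high number in this set.

The compounds shown leave open whether the rise follows the loss of bromine and methoxy or the gain of fluorine and methyl, and how an amine or a longer alkyl chain on this ring would read. Nothing available here gives a reason for the rise.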